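Removing the fluoro from compound 3: what to expect

This account rests on a few compounds, and the source may have more. Where it says the series, first, only, none or still open, it means among the compounds named here.

Measured so far in a functional assay on NCI-H1975 cells (Homo sapiens) for antiproliferative activity, read by MTT assay, with a stated time of 72 h; on this read-out lower numbers stand for stronger inhibition and higher numbers for weaker inhibition:
- compound 1 `C#Cc1cccc(Nc2ncnc3ccc(NC(=S)Nc4ccc(S(N)(=O)=O)cc4)cc23)c1` gives 13400 nM
- compound 2 `NS(=O)(=O)c1ccc(NC(=S)Nc2ccc3ncnc(Nc4ccc(C(F)(F)F)cc4)c3c2)cc1` gives 17100 nM
- compound 3 `NS(=O)(=O)c1ccc(NC(=S)Nc2ccc3ncnc(Nc4cccc(Cl)c4F)c3c2)cc1` gives 25100 nM

Compound 3 has the highest of the three numbers, but its distance to the others is small: the step of a 1.9-fold higher number from compound 1 to compound 3 (0.27 log units; within the scatter) and the step of a 1.5-fold higher number from compound 2 to compound 3 (0.17 log units; within the scatter) both sit within the scatter, as does a 1.3-fold higher number from compound 1 to compound 2 (0.11 log units; within the scatter). On these numbers the three compounds are not told apart.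

Compound 4 `NS(=O)(=O)c1ccc(NC(=S)Nc2ccc3ncnc(Nc4cccc(Cl)c4)c3c2)cc1` differs from compound 3 in one place: hydrogen in place of fluoro on an aromatic carbon. For the measured compounds named here, no measured step removes a single fluoro; the steps that touch the same ring, a 1.9-fold higher number from compound 1 to compound 3 (0.27 log units; within the scatter) and a 1.5-fold higher number from compound 2 to compound 3 (0.17 log units; within the scatter), swap the whole 3-chloro-2-fluorophenyl group and still stay within the scatter. A smaller change is therefore expected to give no step beyond the scatter in this assay, in either direction.

Compound 4 is expected to give 22000 nM, between 10000 nM and 50000 nM, an estimated step of a 1.1-fold lower number from compound 3 to compound 4 (0.06 log units; within the scatter).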

Compound 4, half-maximal inhibitory concentration: 39800 nM
The estimate for compound 4 lay 1.8-fold (0.26 log units) below the measured number, within the range that was stated.
By their numbers in this assay, from the lowest: compounds 1, 2, 3 and 4 (each within the scatter of the next, the first and the last beyond it).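

In this assay, for the compounds shown here, this is the first step that changes a single atom on this ring: hydrogen in place of fluoro on an aromatic carbon, ortho to a chloro group, gives a 1.6-fold higher number from compound 3 to compound 4 (0.20 log units; within the scatter) and so stays inside the usual noise. Going by these compounds alone, the 3-chlorophenyl group also gives the first steps in this set beyond the scatter, with 3-chlorophenyl in place of 4-(trifluoromethyl)phenyl giving a 2.3-fold higher number from compound 2 to compound 4 (0.37 log units; beyond the scatter) and chloro in place of ethynyl giving a 3.0-fold higher number from compound 1 to compound 4 (0.47 log units; beyond the scatter) as a second modest step. Changes on this ring can therefore separate compounds on this read-out, though compound 3 still cannot be told apart from compound 1, compound 2 or compound 4.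

Going by these compounds, whether a methoxy group or a nitrile at the place of the fluoro would move the number further remains open. Nothing given here explains any of these steps.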